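Removing One Methoxy Group from Compound 1

This account rests on a few compounds, and the source may have more. Where it says the series, first, only, none or still open, it means among the compounds named here.

Measured in a functional assay on PC-3 cells (Homo sapiens) for cytotoxicity, read by WST assay, with a stated time of 48 h; on this read-out lower numbers stand for stronger inhibition and higher numbers for weaker inhibition:
- Compound 1 `COc1ccc2c(/C=C(\C#N)C(=O)c3c[nH]c4cc(OC)ccc34)c[nH]c2c1`: 27000 nM
- Compound 2 `N#C/C(=C\c1c[nH]c2ccc(Br)cc12)C(=O)c1c[nH]c2ccc(Br)cc12`: > 50000 nM
- Compound 3 `N#C/C(=C\c1c[nH]c2cc(F)ccc12)C(=O)c1c[nH]c2cc(F)ccc12`: > 50000 nM

For the measured compounds named here, compound 1 holds the only true number in this small set. Compound 2 stands at > 50000 nM, which is a limit of the assay and not a number. Compound 3 stands at > 50000 nM, which is also a limit.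

Compound 4 `COc1ccc2c(/C=C(\C#N)C(=O)c3c[nH]c4ccccc34)c[nH]c2c1` keeps the core of compound 1 with one change: hydrogen in place of methoxy on an aromatic carbon. Hydrogen takes the place of methoxy on an aromatic carbon. Neither compound 2 nor compound 3 carries a methoxy group, and neither gave a number, whereas compound 1 gave 27000 nM. Three compounds are thin evidence, so only a modest loss of inhibition in this assay is expected, perhaps no more than the usual scatter. The expected change is a 1.3-fold higher number from compound 1 to compound 4 (0.11 log units; within the scatter). For compound 4 the estimated value is 35000 nM, with an expected range of 15000 nM to 50000 nM.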

Compound 4, half-maximal inhibitory concentration: 12500 nM
Estimate against measurement, compound 4: 2.8-fold (0.45 log units) above, outside the stated range (below it).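

In this assay, hydrogen in place of methoxy on this aromatic carbon gives a 2.2-fold lower number from compound 1 to compound 4 (0.33 log units; beyond the scatter), so inhibition rises modestly instead of falling. For the compounds shown here, the methoxy group at this place is therefore not needed for the measured effect, something the earlier compounds could not show, since compound 2 and compound 3 each differ from compound 1 in more than one place. This step can be read as a size because both of its ends are true numbers, which cannot be taken for granted in this small set: the limit of > 50000 nM in this assay, at which 2 of the 4 values shown sit.

As far as these compounds go, how a hydroxyl group, an amine or a longer ether such as ethoxy would behave on the same aromatic carbon remains open. Also open, from the compounds shown here alone, is what would happen to the number if the remaining methoxy group of compound 4 were replaced as well.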